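The compounds below may be only part of what the source reports. "The series", "measured", "known", "first", "only" and "open" are said of these compounds alone.

Three compounds that share one core have been run through a functional assay on CHO cells for positive allosteric modulation of muscarinic acetylcholine receptor M5 (Homo sapiens), read by FLIPR and calcium flux, with a stated time of 1 h; on this read-out lower numbers stand for smaller maximal responses and higher numbers for larger maximal responses. Compound 1, `O=C1C(=O)N(Cc2ccc(Cl)nc2)c2ccc(OC(F)(F)F)cc21`, carries a chloropyridinylmethyl group and in this assay gives 80%. Compound 2, `O=C1C(=O)N(Cc2ccc(-c3ccccc3)cn2)c2ccc(OC(F)(F)F)cc21`, extends that pyridine with a phenyl group and in this assay gives 47%. Compound 3, `O=C1C(=O)N(Cc2ccc(-c3cncnc3)cc2)c2ccc(OC(F)(F)F)cc21`, carries a pyrimidin-5-yl group on a benzene ring and in this assay gives 53%.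

On these numbers compound 3 stands second highest of the three. Its nearest neighbour is compound 2, whose value lies only slightly lower and within the usual scatter, so the two cannot be told apart. Its furthest neighbour is compound 1, whose value lies clearly higher, beyond the scatter.

The next compound, compound 4, `O=C1C(=O)N(Cc2ccc(Oc3cccc(F)n3)cc2)c2ccc(OC(F)(F)F)cc21`, is not yet measured. It differs from compound 3 in one place: (6-fluoropyridin-2-yl)oxy in place of pyrimidin-5-yl on an aromatic carbon. Compounds 2 and 3 both carry a larger group at this end of the molecule, and both sit close together in this assay, whereas compound 1 with its smaller group gives 80%. Compound 4 likewise carries a larger group there, so the step from compound 3 to compound 4 is expected to stay within the scatter, a number 2 percentage points higher from compound 3 to compound 4 (within the scatter). The value of compound 4 is therefore estimated at 55%, with a range from 35% to 75%.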

Compound 4, largest response reached (Emax), in percent of the reference or control that the assay uses: 62%
The estimate for compound 4 lay 7 percentage points below the measured number; the measured number falls inside the stated range.
By their numbers in this assay, from the lowest: compounds 2, 3 and 4 (each within the scatter of the next, the first and the last beyond it); then compound 1.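

On the aromatic carbon para to a large group, putting (6-fluoropyridin-2-yl)oxy in place of pyrimidin-5-yl gives, in this assay, a number 9 percentage points higher from compound 3 to compound 4 (within the scatter). This position therefore accepts a real change without a response that can be told apart: the entering group has 8 heavy atoms rather than 6, is joined through an oxygen, carries a fluorine, and has a six-membered aromatic ring with 1 hetero atom rather than 2. Nothing in the available information explains why the response stays within the scatter across this change.

The compounds shown leave open whether the oxygen link or the fluorine matters on its own, which a pyridin-2-yloxy group without the fluorine and a 6-fluoropyridin-2-yl group joined directly to the ring would help to separate. Also open, from the compounds shown here alone, is how far this tolerance extends to quite different groups at the same place, such as an amine or a carboxylic acid, and whether any of them would read differently in this assay.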